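A few compounds are considered here, and "the series" means these few. Any claim that something is new, unique, unknown or untested is made for them only; others in the source may bear on it.

Measured compounds in a functional assay on C6 cells (Rattus norvegicus) for cytotoxicity, read by MTT assay, with a stated time of 24 h, tested at 12 ug/mL; on this read-out higher numbers stand for a weaker effect at the one concentration tested and lower numbers for a stronger effect:
- compound 1, `O=C(CSc1nnnn1-c1ccccc1)N/N=c1/scc(-c2ccc(Br)cc2)n1-c1ccccc1`, gives 58.6%
- compound 2, `Cc1ccc(-c2cs/c(=N/NC(=O)CSc3nnnn3-c3ccccc3)n2-c2ccccc2)cc1`, gives 55.1%
- compound 3, `O=C(CSc1ncccn1)N/N=c1/scc(-c2ccc(Br)cc2)n1-c1ccccc1`, gives 72.1%

Compound 3 stands highest of the three numbers in this assay: the step of a number 13.5 percentage points higher from compound 1 to compound 3 (beyond the scatter) lies beyond the scatter, and compound 2 sits further off still. Compound 1 and compound 2 are within the scatter of each other, so no order is read between them.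

Compound 4, `Cc1ccc(-c2cs/c(=N/NC(=O)CSc3ncccn3)n2-c2ccccc2)cc1`, has not yet been measured. It differs from compound 3 in one place: methyl in place of bromo on an aromatic carbon.

For the measured compounds named here, one measured step bears directly on this change. The same exchange of methyl for bromo on the aromatic carbon, made on the pair carrying 1-phenyl-1H-tetrazol-5-yl on the sulfur, gave a number 3.5 percentage points lower from compound 1 to compound 2 (within the scatter), a shift within the scatter. On that single precedent no step beyond the scatter is expected in this assay on going from compound 3 to compound 4, and the expected step is a number 3.5 percentage points lower from compound 3 to compound 4 (within the scatter). Compound 4 is therefore estimated to give 68.6%, in the range 58% to 79%.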

Compound 4, a percentage reported as activity, at one concentration (the size of the read-out at that concentration, not a potency): 83%
Compound 4: the middle estimate sits 14.4 percentage points below what was measured; the whole stated range lies below it.
By their numbers in this assay, from the lowest: compounds 2 and 1 (each within the scatter of the next); then compound 3; then compound 4.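

In this assay, the exchange of 4-bromophenyl for 4-methylphenyl does not carry over from one group on the sulfur to the other; with pyrimidin-2-yl on the sulfur it gives a number 10.9 percentage points higher from compound 3 to compound 4 (beyond the scatter), so the outcome at this position depends on that group: the same change on two cores in this assay, a number 3.5 percentage points lower (within the scatter) from compound 1 to compound 2 and a number 10.9 percentage points higher (beyond the scatter) from compound 3 to compound 4, 14.4 percentage points apart, beyond the scatter of two such steps. Seen from the sulfur, pyrimidin-2-yl in place of 1-phenyl-1H-tetrazol-5-yl gives a number 27.9 percentage points higher from compound 2 to compound 4 (beyond the scatter) in the methyl pair, a larger step than in the bromo pair: the same change on two cores in this assay, a number 13.5 percentage points higher (beyond the scatter) from compound 1 to compound 3 and a number 27.9 percentage points higher (beyond the scatter) from compound 2 to compound 4, 14.4 percentage points apart, beyond the scatter of two such steps. The two changes therefore do not add up independently across these four compounds.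

Still open, as far as these compounds go, is whether this dependence extends to other groups on the aromatic carbon, such as methoxy or an amine, or to a carboxylic acid on the group carried by the sulfur. With one concentration per compound, the values give no potency order.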